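Aryl exchange on the sulfonyl sulfur: compound 1 to compound 3

The source may report more compounds than this note shows. Statements on the series, on what has been measured and on what is new or still open speak of the compounds shown alone.

Compound 1 `CC1CCN(C2CCN(S(=O)(=O)c3cnc(Cl)s3)CC2)CC1` is the starting point. In a functional assay on DLD-1 cells (Homo sapiens) for antiproliferative activity, read by CellTiter-Glo, with a stated time of 72 h (a lower number here means a stronger inhibitor, a higher number a weaker inhibitor), compound 1 gives 1800 nM. Going by the values given here, the only other measured member, compound 2 `CC(=O)Nc1ccc(S(=O)(=O)N2CCC(N3CCC(C)CC3)CC2)c2ccccc12`, gives 1100 nM in this assay; the two numbers lie within the usual scatter of each other, so neither stands apart. Compound 3 `CC1CCN(C2CCN(S(=O)(=O)c3cncc(Br)c3)CC2)CC1` differs from compound 1 in one place: 5-bromopyridin-3-yl in place of 2-chloro-1,3-thiazol-5-yl on a sulfonyl sulfur. Among the compounds with values here, no measured pair shows what such an exchange does in this assay. With the rest of the molecule kept, a step of about the scatter is expected, with no strong lean in either direction. Compound 3 is therefore estimated at 2500 nM, within 900 nM to 7000 nM. The expected step is a 1.4-fold higher number from compound 1 to compound 3 (0.14 log units; within the scatter).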

Compound 3, half-maximal inhibitory concentration: > 5000 nM
Compound 3 was reported as a limit; the forecaster's own chance of this, stated with the estimate: 5%; middle value at least 2.0-fold (0.30 log units) from the limit.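

In this assay, the aryl group on a sulfonyl sulfur proves not to be freely exchangeable: 5-bromopyridin-3-yl in place of 2-chloro-1,3-thiazol-5-yl gives an at least 2.7-fold higher number from compound 1 to compound 3 (0.44 log units; beyond the scatter). Compound 3 reads > 5000 nM, which is a limit and not a number, so this step gives only a lower bound on the change: the limit of > 5000 nM in this assay, at which 1 of the 3 values shown sits.

This single pair shows one exchange and no trend. The exchange alters ring size, hetero atoms and halogen at once, and the compounds shown do not separate these. Also open, on these data alone, is how a pyridine carrying an amine or a carboxylic acid in place of the bromine would read.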